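From 2,6-Dichlorobenzyl to 2,4-Dichlorobenzyl in Compound 3

This account rests on a few compounds, and the source may have more. Where it says the series, first, only, none or still open, it means among the compounds named here.

Within the data shown here, in a functional assay on MCF7 cells (Homo sapiens) for inhibition, read by MTT assay, with a stated time of 72 h (a lower number here means a stronger inhibitor, a higher number a weaker inhibitor), compound 3 (`C=CCc1ccc(O)c(-c2ccc(OCc3c(Cl)cccc3Cl)c(CC=C)c2)c1`) gives 11500 nM with compound 2 (`C=CCc1ccc(O)c(-c2ccc(OCc3ccc(Cl)c(Cl)c3)c(CC=C)c2)c1`) at 15300 nM as its only numerical neighbour, within the scatter. Compound 1 (`C=CCc1ccc(OCc2ccc(Cl)cc2Cl)c(-c2ccc(OCc3ccc(Cl)cc3Cl)c(CC=C)c2)c1`) reports only a limit (> 50000 nM). Compound 4 (`C=CCc1ccc(O)c(-c2ccc(OCc3ccc(Cl)cc3Cl)c(CC=C)c2)c1`) differs from compound 3 at one place (2,4-dichlorophenyl in place of 2,6-dichlorophenyl on a saturated chain carbon bound to an oxygen on an aromatic ring): 2,4-dichlorophenyl stands in place of 2,6-dichlorophenyl on a saturated chain carbon bound to an oxygen on an aromatic ring. Among the measured compounds shown here, only one measured step bears on this, a swap of dichlorophenyl patterns at the same place that ends at compound 3 (a 1.3-fold lower number from compound 2 to compound 3 (0.12 log units; within the scatter)) and stays within the scatter. No change beyond the scatter is therefore expected (a 1.1-fold higher number from compound 3 to compound 4 (0.05 log units; within the scatter)). Compound 4 is estimated at 13000 nM (expected range 6000 nM to 28000 nM).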

Compound 4, half-maximal inhibitory concentration: 14700 nM
Compound 4: middle estimate off by 1.1-fold (0.05 log units), on the low side; the range from low to high includes it.
By their numbers in this assay, from the lowest: compounds 3, 4 and 2 (each within the scatter of the next). At a limit, above all of these: compound 1.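

Across three dichlorophenyl patterns on this saturated chain carbon, this assay shows no separation, with a 1.3-fold higher number from compound 3 to compound 4 (0.11 log units; within the scatter) and a 1.0-fold lower number from compound 2 to compound 4 (0.02 log units; within the scatter). A step beyond the scatter appears only at the other oxygen on an aromatic ring, where hydrogen stands in place of 2,4-dichlorobenzyl, with an at least 3.4-fold lower number from compound 1 to compound 4 (0.53 log units; beyond the scatter). Compound 1 is known only as a limit: the limit of > 50000 nM in this assay, at which 1 of the 4 values shown sits.

The compounds shown leave open what a plain phenyl, a pyridine or a longer chain would give in place of the dichlorophenyl group. From the compounds shown here alone, the full size of the step from compound 1 also stays open.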